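This account rests on a few compounds, and the source may have more. Where it says the series, first, only, none or still open, it means among the compounds named here.

Of the compounds shown here, three built on one shared core have been tested in a functional assay on RKO cells (Homo sapiens) for cytotoxicity, read by MTT assay, with a stated time of 48 h; on this read-out higher numbers stand for weaker inhibition and lower numbers for stronger inhibition. Compound 1 `CCCCOc1ccc2c(Cl)ccnc2c1` gives 3050 nM. Compound 2 `CN(C)CCNc1ccnc2cc(OCc3ccccc3)ccc12` gives 2350 nM. Compound 3 `C=CCOc1ccc2c(NCCN(C)C)ccnc2c1` gives 1270 nM, the lowest of the three numbers, though its distance to compound 2 lies within the usual scatter and only its distance to compound 1 lies beyond it. Compound 4 `CCCCCCOc1ccc2c(NCCN(C)C)ccnc2c1` has not yet been measured in this assay. It differs from compound 3 in a single place: pentyl in place of vinyl on a saturated chain carbon bound to an oxygen on an aromatic ring. For the measured compounds named here, only one measured step touches that same place, namely a 1.9-fold lower number from compound 2 to compound 3 (0.27 log units; within the scatter), and that change stayed within the scatter. Compound 1 also carries a plain chain at that position, but it differs from the others in a second place as well, so its value shows only that such a chain keeps the number in the same broad region as the rest. Because a 1.9-fold lower number from compound 2 to compound 3 (0.27 log units; within the scatter) stayed within the scatter, the step of a 1.2-fold higher number from compound 3 to compound 4 (0.07 log units; within the scatter) is expected to be small as well, with no clear direction. Compound 4 is therefore estimated at 1500 nM in this assay, within a range from 600 nM to 4000 nM.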

Compound 4, half-maximal inhibitory concentration: 1120 nM
Compound 4: middle estimate off by 1.3-fold (0.13 log units), on the high side; the measured number falls inside the stated range.
By their numbers in this assay, from the lowest: compounds 4, 3, 2 and 1 (each within the scatter of the next, the first and the last beyond it).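

In this assay, exchanging the allyloxy group for the hexyloxy group gives a 1.1-fold lower number from compound 3 to compound 4 (0.05 log units; within the scatter), so a saturated chain with more carbons and no double bond can stand at this position on the shared core without a clear shift in the number. For the compounds shown here, the wider comparison gives a 2.1-fold lower number from compound 2 to compound 4 (0.32 log units; beyond the scatter) and, at a modest size, is the first step at this position to pass beyond the scatter. That separation does not make a plain rule that chains outdo a phenyl group, since compound 3 goes against it: its vinyl group also replaces phenyl, yet its step from compound 2 stays within the scatter.

On these data alone, it remains open whether a chain longer than hexyl, or a chain ending in an amine or a carboxylic acid, would move the number further at this position. Nothing in the available evidence explains why these three groups give such closely spaced numbers.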